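This account rests on a few compounds, and the source may have more. Where it says the series, first, only, none or still open, it means among the compounds named here.

Measured compounds in a functional assay on the whole organism for inhibition, with Mus musculus as the target, at a dose of 10 mg/kg by the oral route; on this read-out lower numbers stand for less inhibition and higher numbers for more inhibition at the one dose given (going by the name of the read-out):
compound 1 `CN1C(=O)/C(=C(/S)N(C)c2ccccc2)C(=O)c2cc(Cl)ccc21` gives 64%; 64% (2 entries)
compound 2 `CN1C(=O)/C(=C(/S)N(C)c2ccc(F)cc2)C(=O)c2cc(Cl)ccc21` gives 54%
compound 3 `CN1C(=O)/C(=C(/S)N(C)c2ccc(Cl)cc2)C(=O)c2cc(Cl)ccc21` gives 47%

Compound 1 carries two entries rather than one single number. Of the two single numbers, compound 3 stands lowest, but its nearest neighbour is compound 2 and the gap between them, a number 7 percentage points lower from compound 2 to compound 3 (within the scatter), lies within the scatter, so no order between compound 2 and compound 3 can be claimed.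

Compound 4 `CN1C(=O)/C(=C(/S)N(C)c2cccc(Cl)c2)C(=O)c2cc(Cl)ccc21` has not been measured in this assay. Compared with compound 3 the change is 3-chlorophenyl in place of 4-chlorophenyl on an amine nitrogen.

For the measured compounds named here, the only step measured is the one from compound 2 to compound 3, a number 7 percentage points lower from compound 2 to compound 3 (within the scatter), which exchanges one halogen for another on the same ring position and stays within the scatter. Going by the values given here, no measured step moves a substituent from one ring position to another, so the change to compound 4 has no direct precedent here. Among the compounds with values here, with the three numbers clustered and the single measured step flat, the expectation for compound 4 is a step of no size beyond the scatter, a number 3 percentage points higher from compound 3 to compound 4 (within the scatter), with the uncertainty spanning the whole range of the measured series. Compound 4 is therefore estimated at 50%, between 35% and 65%.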

Compound 4, a percentage reported as inhibition, in the whole organism at one dose (the size of the read-out at that dose, not a potency): 63%
Compound 4: middle estimate off by 13 percentage points, on the low side; the range from low to high includes it.
By their numbers in this assay, from the lowest: compounds 3, 2 and 4 (each within the scatter of the next, the first and the last beyond it).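

In this assay, for the compounds shown here, 3-chlorophenyl in place of 4-chlorophenyl on the amine nitrogen gives the first step that lies beyond the scatter, a number 16 percentage points higher from compound 3 to compound 4 (beyond the scatter), so the place of the chlorine on this ring matters more than the one halogen exchange measured earlier. Going by these compounds alone, the comparison with the fluorinated analogue is less clear: a number 9 percentage points higher from compound 2 to compound 4 (within the scatter), so only the step from the 4-chlorophenyl compound separates the new compound from its neighbours, and compound 4 at 63% stands close to the unsubstituted phenyl compound 1 at 64%; 64% (2 entries). No measurement is at hand that bears on why the two chlorophenyl isomers differ.

Going by these compounds, whether this sensitivity to the chlorine's place carries over to other substituents remains open, for example a methoxy group, a nitrile or a trifluoromethyl group in place of that chlorine. Also open, on these data alone, is how far the read-out depends on the saturated chain carbon on the amine nitrogen, which a longer chain such as ethyl or propyl in its place would test.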